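Swapping the ethoxymethyl group of compound 3

The source may hold more compounds than are shown below. What is called first, only, known or untested is meant among the compounds shown, and "the series" means these compounds.

Values in an ADME assay on HepG2 2.2.15 cells (Homo sapiens) for cytotoxicity; on this read-out lower numbers stand for higher toxicity in this test and higher numbers for lower toxicity in this test:
- compound 1 `O=c1[nH]c2ccc(Cl)cc2c(-c2ccccc2Cl)c1CCO` gives 380000 nM
- compound 2 `CC(=O)OCCc1c(-c2ccccc2Cl)c2cc(Cl)ccc2[nH]c1=O` gives 27000 nM
- compound 3 `CCOCC(=O)OCCc1c(-c2ccccc2Cl)c2cc(Cl)ccc2[nH]c1=O` gives 130000 nM

Going by the values given here, of the three numbers, the one for compound 3 is the second highest, lying below that of compound 1 and above that of compound 2. The next compound, compound 4 `CC(=O)N1CCC(C(=O)OCCc2c(-c3ccccc3Cl)c3cc(Cl)ccc3[nH]c2=O)CC1`, carries 1-acetylpiperidin-4-yl in place of ethoxymethyl on a carbonyl carbon. Among the compounds with values here, three measured steps bear on this site. Acetyl in place of the hydrogen on the oxygen gave a 14-fold lower number from compound 1 to compound 2 (1.15 log units; beyond the scatter), while (ethoxymethyl)carbonyl there gave a 2.9-fold lower number from compound 1 to compound 3 (0.47 log units; beyond the scatter). Ethoxy added to the acetyl gave a 4.8-fold higher number from compound 2 to compound 3 (0.68 log units; beyond the scatter). These steps show that this site can shift the number, but none of them tells the direction for a ring-bearing group. Compound 2 and compound 3 both lie below compound 1, and the new group is expected to keep compound 4 in that region, with no step beyond the scatter. The expected step is a 1.4-fold lower number from compound 3 to compound 4 (0.16 log units; within the scatter). For compound 4 the estimated value is 90000 nM, with an expected range from 30000 nM to 270000 nM.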

Compound 4, half-maximal cytotoxic concentration: 82000 nM
Beside the measured number, compound 4's estimate is 1.1-fold (0.04 log units) above it, and the stated range covers the measured number.
By their numbers in this assay, from the lowest: compound 2; then compounds 4 and 3 (each within the scatter of the next); then compound 1.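

In this assay the ring-bearing 1-acetylpiperidin-4-yl on the carbonyl carbon, in place of the open-chain ethoxymethyl, gave a 1.6-fold lower number from compound 3 to compound 4 (0.20 log units; within the scatter) and so showed that this position can hold a six-membered non-aromatic ring without a step beyond the scatter. The same group, in place of the methyl of compound 2, gave a 3.0-fold higher number from compound 2 to compound 4 (0.48 log units; beyond the scatter) and, set against the hydrogen of compound 1, gave a 4.6-fold lower number from compound 1 to compound 4 (0.67 log units; beyond the scatter) in this series, which places compound 4 with compound 3 and apart from both of those compounds. No measurement shown here offers an explanation for these steps. As far as these compounds go, whether an amine or a carboxylic acid on the carbonyl carbon would stay with compound 3 and compound 4 remains open. So does the part played by the acetyl on the ring nitrogen of 1-acetylpiperidin-4-yl.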